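The source may report more compounds than this note shows. Statements on the series, on what has been measured and on what is new or still open speak of the compounds shown alone.

Measured in an ADME assay on HepG2 cells (Homo sapiens) for cytotoxicity, read by sulforhodamine B assay, with a stated time of 48 h; a higher number here means that more compound is tolerated, a lower number that less compound is tolerated:
compound 1, `COc1nc2ccccc2cc1/C=C/c1noc(-c2ccc(C)cc2)n1`, gives > 230000 nM, which is a limit of the assay.
compound 2, `COc1nc2ccccc2cc1/C=C/c1noc(-c2ccc(F)cc2)n1`, gives > 230000 nM, which is a limit of the assay.
compound 3, `COc1ccccc1-c1nc(/C=C/c2cc3ccccc3nc2OC)no1`, gives > 220000 nM, which is a limit of the assay.

Compound 2 stands at the limit of > 230000 nM in this assay, at which 2 of the 3 values shown sit. The two further values shown are also limits, one of them at the limit of > 220000 nM in this assay, at which 1 of the 3 values shown sits. Among the compounds with values here, since no compound gave a number inside the tested range, the steps between them cannot be read: a step that the two limits leave unreadable from compound 1 to compound 2, a step that the two limits leave unreadable from compound 1 to compound 3 and a step that the two limits leave unreadable from compound 2 to compound 3 are all of unreadable size, which means only that each change left the value at a limit.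

Compound 4, `COc1nc2ccccc2cc1/C=C/c1noc(-c2cccc(C)c2)n1`, differs from compound 2 by 3-methylphenyl in place of 4-fluorophenyl on an aromatic carbon. Within the data shown here, the steps that bear on this change are those from compound 1 to compound 2 and from compound 2 to compound 3, where a change on the same aromatic carbon did not bring any compound below the limit. The expected step from compound 2 to compound 4 in this assay is a step that the limit leaves unreadable from compound 2 to compound 4, that is, none beyond the scatter. Compound 4 is expected to give about 250000 nM, with a range from 150000 nM to 500000 nM, and most probably once more only a limit.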

Compound 4, half-maximal cytotoxic concentration: > 230000 nM
Compound 4 was reported as a limit (the forecaster's own chance of this, stated with the estimate: 85%); the middle value is on the limit's open side.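

In this assay compound 4 gives > 230000 nM, which is a limit of the assay, so its steps from compound 1, compound 2 and compound 3 cannot be read. The compounds shown leave open the concentration at which any of them would reach the half-maximal cytotoxic effect, and whether changing the aryl group alters it.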